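The compounds below may be only part of what the source reports. "The series", "measured", "known", "first", "only" and "open" are said of these compounds alone.

Measured compounds:
- compound 1 `CC(C)=CCCN(C)C1CCN(CCCc2c[nH]c3ccc(-n4cnnc4)cc23)CC1` with 24 nM
- compound 2 `CC(=O)Nc1ccc(CNC2CCN(CCCc3c[nH]c4ccc(-n5cnnc5)cc34)CC2)cc1` with 45 nM
- compound 3 `C[C@@H](NC1CCN(CCCc2c[nH]c3ccc(-n4ccnc4)cc23)CC1)c1ccccc1` with 110 nM

In an assay on CHO cells for displacement of a labelled ligand from 5-hydroxytryptamine receptor 1B (Homo sapiens) (on this read-out lower numbers stand for stronger inhibition and higher numbers for weaker inhibition), compound 1 gives the lowest of the three numbers. Compound 2 sits nearest to it, within the scatter, while compound 3 lies furthest, beyond the scatter. The step to compound 4 `C[C@H](NCC1CCN(CCCc2c[nH]c3ccc(-n4cnnc4)cc23)CC1)c1ccccc1` replaces one group on a saturated ring carbon of the shared core: ((1-phenylethyl)amino)methyl in place of methyl(4-methylpent-3-en-1-yl)amino on a saturated ring carbon. For the measured compounds named here, no measured pair shows this change directly, so the expectation rests on compound 3, which carries a related 1-phenylethyl amine and gives a higher number than compound 1. In this assay the step is expected to be towards weaker inhibition by an amount beyond the scatter, a 3.8-fold higher number from compound 1 to compound 4 (0.57 log units; beyond the scatter). Compound 4 is therefore estimated at 90 nM, with a range from 25 nM to 320 nM.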

Compound 4, half-maximal inhibitory concentration: 58 nM
Compound 4: the middle estimate sits 1.6-fold (0.19 log units) above what was measured; the measured number falls inside the stated range.
By their numbers in this assay, from the lowest: compounds 1, 2, 4 and 3 (each within the scatter of the next, the first and the last beyond it).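

In this assay the exchange at this saturated ring carbon gives a 2.4-fold higher number from compound 1 to compound 4 (0.38 log units; beyond the scatter) and so a modest step beyond the scatter. The position therefore still gives a measurable number when the open-chain methyl(4-methylpent-3-en-1-yl)amino group gives way to ((1-phenylethyl)amino)methyl, which brings in an aromatic ring, a hydrogen-bond donor and a defined stereocentre. Nothing measured here says what lies behind the step.

The compounds shown leave open how the opposite configuration at that stereocentre would read. They also leave open whether a morpholine or a carboxylic acid in this group would shift the number.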